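Catechol for bromophenyl on the shared core

The source may report more compounds than this note shows. Statements on the series, on what has been measured and on what is new or still open speak of the compounds shown alone.

The series rests on the shared core of compound 1 `COc1cccc(/C=C2\CCC/C(=C\c3ccc(O)c(O)c3)C2=O)c1OC`, which in a functional assay on HT-1080 cells (Homo sapiens) for cytotoxicity, read by MTT assay, with a stated time of 72 h (on this read-out higher numbers stand for weaker inhibition and lower numbers for stronger inhibition), gives 4700 nM. Among the compounds with values here, compound 2 `COc1ccc(/C=C2\CCC/C(=C\c3cccc(Br)c3)C2=O)cc1OC` in this assay gives 5200 nM; this is the higher of the two numbers measured so far, but its gap to compound 1 lies within the scatter, so the two compounds cannot be ordered. Compound 3 `COc1ccc(/C=C2\CCC/C(=C\c3ccc(O)c(O)c3)C2=O)cc1OC` is not yet measured in this assay. It differs from compound 2 in one place: 3,4-dihydroxyphenyl in place of 3-bromophenyl on a double-bonded chain carbon bound to a double-bonded ring carbon. Within the data shown here, no step between measured compounds covers this change, and compound 1 already carries the entering group while giving a number close to that of compound 2. The expected step in this assay is therefore a 1.2-fold lower number from compound 2 to compound 3 (0.06 log units; within the scatter), nothing beyond the scatter in either direction. On this basis compound 3 is estimated to give 4500 nM in this assay, with a range from 2000 nM to 10000 nM.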

Compound 3, half-maximal inhibitory concentration: 4200 nM
Beside the measured number, compound 3's estimate is 1.1-fold (0.03 log units) above it, and the stated range covers the measured number.
By their numbers in this assay, from the lowest: compounds 3, 1 and 2 (each within the scatter of the next).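

In this assay the exchange of 3-bromophenyl for 3,4-dihydroxyphenyl on a double-bonded chain carbon bound to a double-bonded ring carbon now has a direct reading, a 1.2-fold lower number from compound 2 to compound 3 (0.09 log units; within the scatter), which compound 1 and compound 2 could not give, as they differ in more than one place. In this one pair the position takes either group with no readable change, although the hydrogen-bond donors and acceptors counted for the two groups differ. No evidence is at hand on why the two groups read alike.

Open, going by these compounds, is whether a phenyl ring carrying an amine or a carboxylic acid in place of the bromine or the hydroxyl groups would read the same. Also open, on these data alone, is whether this exchange reads alike on other cell lines.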